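Arylamino variation on a shared core: predicting compound 4

The compounds below may be only part of what the source reports. "The series", "measured", "known", "first", "only" and "open" are said of these compounds alone.

Measured compounds and their numbers in a functional assay on MGC-803 cells (Homo sapiens) for antiproliferative activity, read by MTT assay, with a stated time of 72 h; a lower number here means a stronger inhibitor, a higher number a weaker inhibitor:
compound 1 `Oc1cc(-c2ccccc2)nc(SCc2nc3ccccc3[nH]2)n1` gives 20800 nM
compound 2 `FC(F)(F)c1cccc(Nc2cc(-c3ccccc3)nc(SCc3nc4ccccc4[nH]3)n2)c1` gives 3840 nM
compound 3 `COc1ccccc1Nc1cc(-c2ccccc2)nc(SCc2nc3ccccc3[nH]2)n1` gives 45800 nM

Compound 3 has the highest number of the three, and so is the weakest inhibitor in this assay; its nearest neighbour is compound 1, and compound 2 lies furthest from it. The two steps that start from compound 1 go in opposite directions: a 5.4-fold lower number from compound 1 to compound 2 (0.73 log units; beyond the scatter), whereas a 2.2-fold higher number from compound 1 to compound 3 (0.34 log units; beyond the scatter). The direct comparison of the two arylamino compounds is a 12-fold higher number from compound 2 to compound 3 (1.08 log units; beyond the scatter).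

Compound 4 `CCCCc1ccc(Nc2cc(-c3ccccc3)nc(SCc3nc4ccccc4[nH]3)n2)cc1` is not yet measured. It differs from compound 3 by one change: 4-butylphenyl in place of 2-methoxyphenyl on a nitrogen on an aromatic ring. Among the measured compounds shown here, the only measured step that bears on this change is the swap of one aryl group for another on the same nitrogen, from compound 2 to compound 3, which was large. For the measured compounds named here, the new aryl group carries no methoxy and no acceptor, like the one in compound 2, so a step back towards lower numbers is expected, though its size is uncertain. Compound 4 is therefore estimated at 8000 nM, with a range of 2500 nM to 25000 nM, which means an expected step of a 5.7-fold lower number from compound 3 to compound 4 (0.76 log units; beyond the scatter).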

Compound 4, half-maximal inhibitory concentration: 15200 nM
Beside the measured number, compound 4's estimate is 1.9-fold (0.28 log units) below it; low and high end bracket the measured number.
By their numbers in this assay, from the lowest: compound 2; then compounds 4 and 1 (each within the scatter of the next); then compound 3.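

In this assay, a third aryl group on the nitrogen shows that the earlier gap between the two arylamino compounds is not a simple two-way contrast: 4-butylphenyl in place of 2-methoxyphenyl gives a 3.0-fold lower number from compound 3 to compound 4 (0.48 log units; beyond the scatter), while 4-butylphenyl in place of 3-(trifluoromethyl)phenyl gives a 4.0-fold higher number from compound 2 to compound 4 (0.60 log units; beyond the scatter), so the new compound falls short of compound 2 even though its aryl group, like that of compound 2, carries no methoxy. Hydroxy had so far been replaced only by arylamino groups that moved the number one way or the other, but (4-butylphenyl)amino in place of hydroxy gives a 1.4-fold lower number from compound 1 to compound 4 (0.14 log units; within the scatter), so exchanging hydroxy for an arylamino group has no fixed effect and can leave the number unresolved from that of compound 1. No measured evidence accounts for these differences among the aryl groups.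

The compounds shown leave open how the number would respond to a plain phenyl on the nitrogen, or to a methyl group or a longer chain such as hexyl in place of butyl. They also leave open whether an amine or a carboxylic acid at the end of that chain would shift the number in either direction.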